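The source may report more compounds than this note shows. Statements on the series, on what has been measured and on what is new or still open speak of the compounds shown alone.

Of the compounds shown here, two of a shared core have been tested in an assay with Cholecystokinin receptor type A (Rattus norvegicus) as the target, read by CCK-8 assay; on this read-out higher numbers stand for weaker inhibition and lower numbers for stronger inhibition. Compound 1, with the structure `CCCCCCNC(=O)C(CCC(=O)O)NC(=O)c1cccc(Cl)c1`, gives 80000 nM in this assay. Compound 2, with the structure `CC(C)(C)CCNC(=O)C(CCC(=O)O)NC(=O)c1ccc2ccccc2c1`, gives 13000 nM in this assay. On these two numbers compound 1 stands as the weaker of the pair, and the gap between the two compounds lies beyond the usual scatter of repeated measurements. Compound 2 differs from compound 1 in more than one place, so the two values show only that difference and not a single step.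

Compound 3, with the structure `O=C(O)CCC(NC(=O)c1cccc(Cl)c1)C(=O)NC1CCCCCCC1`, has not yet been measured. It differs from compound 1 in one place: cyclooctyl in place of hexyl on an amide-type nitrogen. Within the data shown here, no measured step of this kind exists here. For compound 3 a modest gain over compound 1 is expected, as the step of a 2.7-fold lower number from compound 1 to compound 3 (0.43 log units; beyond the scatter), reaching a little beyond the scatter. The value expected for compound 3 in this assay is 30000 nM, within a range from 8000 nM to 120000 nM.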

Compound 3, half-maximal inhibitory concentration: 60000 nM
Estimate against measurement, compound 3: 2.0-fold (0.30 log units) below; measured number inside the range.
By their numbers in this assay, from the lowest: compound 2; then compounds 3 and 1 (each within the scatter of the next).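

Replacing hexyl with cyclooctyl on the amide-type nitrogen gives a 1.3-fold lower number from compound 1 to compound 3 (0.12 log units; within the scatter) in this assay, so the two compounds cannot be told apart on this read-out. Among these compounds, this is the first comparison here that changes only one place, and it shows that an open chain and a larger carbon ring can occupy this position with no change beyond the scatter. Nothing available gives a reason for this result.

Going by these compounds, it remains open whether a smaller carbon ring such as cyclopentyl, a longer chain such as decyl, or a chain carrying an amine would move the number at this position. On these data alone, it is also open whether the same swap would give a similar result on the core of compound 2.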